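This account rests on a few compounds, and the source may have more. Where it says the series, first, only, none or still open, it means among the compounds named here.

The measured compounds so far:

Compound 1, `COc1ccc2[nH]c(C)c(Cc3ccccc3)c(=O)c2c1`: 167 10^-6 cm/s
Compound 2, `Cc1[nH]c2ccc(Cl)cc2c(=O)c1Cc1ccccc1`: 422 10^-6 cm/s
Compound 3, `COc1cccc2[nH]c(C)c(Cc3ccccc3)c(=O)c12`: 69.8 10^-6 cm/s

All three were tested in an ADME assay for permeability, using PAMPA, at pH 4; a higher number here means that the compound crosses the layer faster, a lower number that the compound crosses the layer more slowly. Compound 1 and compound 2 share a core and differ in one place only: chloro in place of methoxy on an aromatic carbon. That single change gave a 2.5-fold higher number from compound 1 to compound 2 (0.40 log units; beyond the scatter), so compound 2 crosses the layer faster than compound 1 by a clear margin.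

Compound 3 has the same atoms as compound 1 joined differently; the difference between the two cores is not broken down here. In this assay compound 3 gives the lowest of the three numbers, with compound 1 nearest to it and compound 2 furthest away.

Compound 4, `Cc1[nH]c2cccc(Cl)c2c(=O)c1Cc1ccccc1`, has not yet been measured. It stands to compound 3 as compound 2 stands to compound 1: chloro in place of methoxy on an aromatic carbon. This is the same kind of change as that from compound 1 to compound 2, but not the same: in compound 2 the chloro sits meta to a fused ring and para to a fused ring, whereas in compound 4 it sits ortho to a fused ring and meta to a fused ring.

For the measured compounds named here, the only guide is the one earlier instance. Because compound 2 showed a 2.5-fold higher number from compound 1 to compound 2 (0.40 log units; beyond the scatter), a step of similar size is expected from compound 3 to compound 4, namely a 2.3-fold higher number from compound 3 to compound 4 (0.36 log units; beyond the scatter). The shift in where the chloro sits adds uncertainty, and the range is set wide for that reason. In this assay compound 4 is therefore estimated at 160 10^-6 cm/s, expected to fall between 70 10^-6 cm/s and 350 10^-6 cm/s.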

Compound 4, apparent permeability: 244 10^-6 cm/s
Estimate against measurement, compound 4: 1.5-fold (0.18 log units) below; the range from low to high includes it.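

In this assay, chloro in place of methoxy on an aromatic carbon gave a 3.5-fold higher number from compound 3 to compound 4 (0.54 log units; beyond the scatter), so the number rose on this core as it did on the core of compound 1. Set side by side, the two steps can be treated as the same size, even though the group sits at a different place on each core: the same change on two cores in this assay, a 2.5-fold higher number (0.40 log units; beyond the scatter) from compound 1 to compound 2 and a 3.5-fold higher number (0.54 log units; beyond the scatter) from compound 3 to compound 4, 1.4-fold (0.14 log units) apart, within the scatter of two such steps. For the compounds shown here, in this series, then, the change carried over from one core to the other in both direction and size, but this rests on only two pairs of compounds, so it does not show that the step would hold on a further core, and it does not explain why the number rises.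

From the compounds shown here alone, only methoxy and chloro have been compared here, so it remains open whether a different group on the same aromatic carbon, such as an amine, a carboxylic acid or a longer chain like propoxy, would give a number in line with either of them. Going by these compounds, it is also open whether the step between methoxy and chloro would keep its size at other places on the core than the two seen in these four compounds.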